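Pyridin-2-yl replacing a dimethoxyphenyl ketone on the shared core

A few compounds are considered here, and "the series" means these few. Any claim that something is new, unique, unknown or untested is made for them only; others in the source may bear on it.

Compound 1, `COc1ccc(-c2cc3ccccc3nc2C=O)cc1`, gives in a functional assay on NCI-H460 cells (Homo sapiens) for antiproliferative activity, read by XTT assay, with a stated time of 72 h (on this read-out lower numbers stand for stronger inhibition and higher numbers for weaker inhibition), only a limit, > 10000 nM, and no number. Compound 2, `COc1ccc(-c2cc3ccccc3nc2/C=C/C(=O)c2ccc(OC)cc2OC)cc1`, gives in this assay 7040 nM. Compound 3, `COc1ccc(-c2cc3ccccc3nc2/C=C/C(=O)c2ccc(OC)c(OC)c2)cc1`, gives in this assay 7540 nM.

Among the numbers shown, compound 3 holds the highest value, though its nearest neighbour compound 2 sits within the scatter of it, so no order between the two can be read; the limit for compound 1 the limit of > 10000 nM in this assay, at which 1 of the 3 values shown sits, stands apart from both. Compound 4, `COc1ccc(-c2cc3ccccc3nc2/C=C/C(=O)c2ccccn2)cc1`, has not been measured yet. It differs from compound 3 in a single place: pyridin-2-yl in place of 3,4-dimethoxyphenyl on a carbonyl carbon. Among the compounds with values here, only one measured step bears on this change, the swap of one aryl group for another on the same carbonyl carbon, a 1.1-fold higher number from compound 2 to compound 3 (0.03 log units; within the scatter), and that step was within the scatter. The move to pyridin-2-yl removes both methoxy groups rather than shifting one, so the precedent is looser, but nothing measured here points to a large shift in either direction. Compound 4 is therefore expected to give a number close to that of compound 3, a step of a 1.0-fold lower number from compound 3 to compound 4 (0.00 log units; within the scatter). Compound 4 is estimated at 7500 nM in this assay, within a range of 2500 nM to 22000 nM.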

Compound 4, half-maximal inhibitory concentration: 6260 nM
Compound 4: middle estimate off by 1.2-fold (0.08 log units), on the high side; the range from low to high includes it.
By their numbers in this assay, from the lowest: compounds 4, 2 and 3 (each within the scatter of the next). At a limit, above all of these: compound 1.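

Within the data shown here, until now, the only exchange on this carbonyl carbon was one dimethoxyphenyl group for another, a 1.1-fold higher number from compound 2 to compound 3 (0.03 log units; within the scatter), so both methoxy groups and the carbon-only ring were always present. Compound 4 shows that a much plainer exchange leaves the reading just as unresolved in this assay, with pyridin-2-yl carrying a ring nitrogen and neither methoxy group: a 1.2-fold lower number from compound 3 to compound 4 (0.08 log units; within the scatter), and a 1.1-fold lower number from compound 2 to compound 4 (0.05 log units; within the scatter). Among these compounds, then, neither the methoxy groups nor a carbon-only ring on the carbonyl carbon is required for a value at this level, and nothing measured here explains why the exchange leaves the number unresolved.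

Among these compounds, compound 1 gives only a limit, > 10000 nM, so no step from it can be read. Going by these compounds, since compounds 2, 3 and 4 cannot be told apart, it remains open whether any group on this carbonyl carbon can move the number beyond the scatter, such as an unsubstituted phenyl, a pyridin-3-yl, an aminoalkyl chain or a phenyl bearing a carboxylic acid.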